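From Cyclohexyl to Pyridinyl on an Amide Nitrogen

The compounds below may be only part of what the source reports. "The series", "measured", "known", "first", "only" and "open" are said of these compounds alone.

Of the compounds shown here, two have been measured in an assay on HEK293 cells for agonist activity at transient receptor potential cation channel subfamily M member 8 (Homo sapiens), read by fluorescence and calcium flux, with a stated time of 15 min; a higher number here means that more compound is needed for the effect, a lower number that less compound is needed. Compound 1 `Cc1ccc(OCC(=O)N(Cc2cccs2)c2ccn(C)n2)cc1` gives 855 nM, and compound 2 `Cc1ccc(OCC(=O)N(Cc2cccs2)C2CCCCC2)cc1` gives 40000 nM. Compound 2 therefore stands at the higher of the two numbers, meaning more of it is needed for the same effect than of compound 1. Going by the values given here, the only step so far, a 47-fold higher number from compound 1 to compound 2 (1.67 log units; beyond the scatter), shows that putting cyclohexyl in place of 1-methyl-1H-pyrazol-3-yl on the amide-type nitrogen raised the number strongly.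

Compound 3 `Cc1ccc(OCC(=O)N(Cc2cccs2)c2ccccn2)cc1` has not yet been measured. It differs from compound 2 in one place: pyridin-2-yl in place of cyclohexyl on an amide-type nitrogen. This returns an aromatic ring with one hetero atom to the same nitrogen, as compound 1 carries, so the step from compound 1 to compound 2 bears on it directly and points to a large move back down in this assay. The step is expected to be about a 27-fold lower number from compound 2 to compound 3 (1.43 log units; beyond the scatter). Compound 3 is therefore estimated at 1500 nM, within a range from 300 nM to 8000 nM.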

Compound 3, half-maximal effective concentration: 200 nM
Beside the measured number, compound 3's estimate is 7.5-fold (0.88 log units) above it; measured number outside the range, below it.
By their numbers in this assay, from the lowest: compound 3; then compound 1; then compound 2.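

Putting pyridin-2-yl in place of cyclohexyl on the amide-type nitrogen gives a 200-fold lower number from compound 2 to compound 3 (2.30 log units; beyond the scatter) in this assay and so shows that the earlier drop in the number was not special to 1-methyl-1H-pyrazol-3-yl. The choice of aromatic ring also counts, and not only its presence: pyridin-2-yl in place of 1-methyl-1H-pyrazol-3-yl gives a 4.3-fold lower number from compound 1 to compound 3 (0.63 log units; beyond the scatter) and is a modest step, but one that this position does register. Among these three compounds, both aromatic rings give lower numbers than cyclohexyl, and none goes against that.

Phenyl, which has no ring nitrogen, or pyridin-3-yl, which has it elsewhere in the ring, would show whether the ring nitrogen matters or an aromatic ring alone is enough. Nothing available here explains the size of these steps.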